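This account rests on a few compounds, and the source may have more. Where it says the series, first, only, none or still open, it means among the compounds named here.

Measured in an assay on Cerebral cortex for binding affinity to adenosine receptor A1 (Cavia porcellus), read by radioligand binding; a higher number here means a weaker inhibitor, a lower number a stronger inhibitor:
Compound 1 `CCCn1c(=O)n(CCCN(C)C)c(=O)c2[nH]cnc21`: 43200 nM.
Compound 2 `CCCn1c(=O)n(CCCCC(C)=O)c(=O)c2[nH]cnc21`: 23100 nM.
Compound 3 `CCCn1c(=O)n(C)c(=O)c2c1ncn2CCC(=O)O`: > 200000 nM, a limit of the assay and not a number.

Compound 3 therefore stands at the limit of > 200000 nM in this assay, at which 1 of the 3 values shown sits, and cannot be ranked against compounds 1 and 2 beyond that. Compound 4 `CCCn1c(=O)n(C)c(=O)c2c1ncn2CCOC` differs from compound 3 by methoxy in place of carboxy on a saturated chain carbon, two bonds along the chain from an aromatic nitrogen. For the measured compounds named here, the only measured step, a 1.9-fold lower number from compound 1 to compound 2 (0.27 log units; within the scatter), concerns the other chain of the shared core and offers no close guide here, and compound 3 gives no number to step from. Compound 4 is expected to move by roughly an at least 2.5-fold lower number from compound 3 to compound 4 (0.39 log units; beyond the scatter), as a working guess only. For compound 4 the expected value in this assay is 80000 nM, within 20000 nM to 300000 nM, with a real chance that only a limit is returned again.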

Compound 4, inhibition constant: 12400 nM
For compound 4 the middle estimate is 6.5-fold (0.81 log units) above the measured one; measured number outside the range, below it.
By their numbers in this assay, from the lowest: compounds 4, 2 and 1 (each within the scatter of the next, the first and the last beyond it). At a limit, above all of these: compound 3.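

In this assay methoxy in place of carboxy on a saturated chain carbon, two bonds along the chain from an aromatic nitrogen, gives an at least 16-fold lower number from compound 3 to compound 4 (1.20 log units; beyond the scatter) and provides the first step read at this position. On these data alone, compound 3 stands at a limit and not a number, so the full size of the step stays unknown: the limit of > 200000 nM in this assay, at which 1 of the 4 values shown sits.

The compounds shown leave open how an amine, a hydroxy group or a longer ether chain would read at this position. As far as these compounds go, whether the same change holds on the other chain of the shared core also stays open.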